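A Methyl Added to the Double-Bonded Chain Carbon

A few compounds are considered here, and "the series" means these few. Any claim that something is new, unique, unknown or untested is made for them only; others in the source may bear on it.

Compound 1 `CC(C)=C1C(=O)N(c2ccc(Cl)cc2)N(c2ccc(Cl)cc2)C1=O`: 45600 nM
Compound 2 `CCC(C)=C1C(=O)N(c2ccc(Cl)cc2)N(c2ccc(Cl)cc2)C1=O`: 49200 nM
Compound 3 `O=C1C(=Cc2ccc(O)cc2)C(=O)N(c2ccc(Cl)cc2)N1c1ccc(Cl)cc1`: 20600 nM

In a functional assay on SMMC-7721 cells (Homo sapiens) for cytotoxicity, read by MTT assay, with a stated time of 72 h (on this read-out higher numbers stand for weaker inhibition and lower numbers for stronger inhibition), compound 3 gives 20600 nM, the lowest of the three numbers, and its gaps to compound 1 and compound 2 both lie beyond the scatter. Compound 4 `CC(=C1C(=O)N(c2ccc(Cl)cc2)N(c2ccc(Cl)cc2)C1=O)c1ccc(O)cc1` differs from compound 3 by one change, methyl in place of hydrogen on a double-bonded chain carbon bound to an aromatic carbon and a double-bonded ring carbon: a methyl in place of hydrogen on a double-bonded chain carbon bound to an aromatic carbon and a double-bonded ring carbon.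

Within the data shown here, only one measured step also swaps a hydrogen for a methyl: a 1.1-fold higher number from compound 1 to compound 2 (0.03 log units; within the scatter). That step is small, but it sits on a saturated chain carbon, so it is only a loose guide. Compound 1 and compound 2 also have no hydrogen on the double-bonded chain carbon, and both show higher numbers than compound 3. However, they differ from compound 3 in more than one place, so this is a weak hint at most.

No step beyond the scatter is therefore expected, with a slight lean towards a higher number: the expected step is a 1.3-fold higher number from compound 3 to compound 4 (0.12 log units; within the scatter). Compound 4 is estimated at 27000 nM, with an expected range of 12000 nM to 60000 nM.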

Compound 4, half-maximal inhibitory concentration: 57000 nM
Compound 4: the middle estimate sits 2.1-fold (0.32 log units) below what was measured; the measured number falls inside the stated range.
By their numbers in this assay, from the lowest: compound 3; then compounds 1, 2 and 4 (each within the scatter of the next).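

In this assay, a methyl in place of hydrogen on a double-bonded chain carbon bound to an aromatic carbon and a double-bonded ring carbon gives a 2.8-fold higher number from compound 3 to compound 4 (0.44 log units; beyond the scatter), the first single change shown here that reaches beyond the scatter, whereas the earlier hydrogen-to-methyl swap on a saturated chain carbon gave a 1.1-fold higher number from compound 1 to compound 2 (0.03 log units; within the scatter). Once this carbon carries no hydrogen, the group on it seems to count for little: 4-hydroxyphenyl in place of ethyl gives a 1.2-fold higher number from compound 2 to compound 4 (0.06 log units; within the scatter), and 4-hydroxyphenyl in place of methyl gives a 1.3-fold higher number from compound 1 to compound 4 (0.10 log units; within the scatter), so compound 3, the only one with a hydrogen there, stands apart from the other three, and none of the four goes against this. Nothing measured here explains why this one added methyl shifts the number.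

Among these compounds, compound 3 is the sole example with that hydrogen, so it remains open whether a hydrogen on this carbon lowers the number with other groups, such as a 4-aminophenyl in place of the 4-hydroxyphenyl. Also open, on these data alone, is whether a longer chain, such as propyl in place of the methyl of compound 4, would leave the number within the scatter.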